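Aryl swap on the shared core, cytotoxicity in HL-60 cells

This account rests on a few compounds, and the source may have more. Where it says the series, first, only, none or still open, it means among the compounds named here.

Compound 1 `COCOc1ccccc1C[C@H]1C(=O)OC[C@@H]1Cc1ccccc1` gives 76000 nM in a functional assay on HL-60 cells (Homo sapiens) for cytotoxicity, read by WST assay, with a stated time of 48 h; a lower number here means that less compound is needed, a higher number that more compound is needed for the effect.
Compound 2 `O=C1OC[C@H](Cc2ccccc2)[C@H]1Cc1ccccc1F` gives 72000 nM in this assay.

Compound 2 stands beside compound 1 in this assay, the two numbers within the scatter of each other: a 1.1-fold lower number from compound 1 to compound 2 (0.02 log units; within the scatter). Compound 3 `Cc1ccc(C[C@H]2C(=O)OC[C@@H]2Cc2ccccc2)cc1` differs from compound 2 by 4-methylphenyl in place of 2-fluorophenyl on a saturated chain carbon bound to a saturated ring carbon. Going by the values given here, the only measured step on this aryl group, from compound 1 to compound 2, stayed within the scatter, so for compound 3 no step beyond the scatter is expected in this assay, a 1.0-fold lower number from compound 2 to compound 3 (0.01 log units; within the scatter). Compound 3 is estimated at 70000 nM, range 25000 nM to 200000 nM.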

Compound 3, half-maximal effective concentration: 44000 nM
Compound 3: the middle estimate sits 1.6-fold (0.20 log units) above what was measured; low and high end bracket the measured number.
By their numbers in this assay, from the lowest: compounds 3, 2 and 1 (each within the scatter of the next).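

In this assay, 4-methylphenyl in place of 2-fluorophenyl on a saturated chain carbon bound to a saturated ring carbon gives a 1.6-fold lower number from compound 2 to compound 3 (0.21 log units; within the scatter). This position therefore tolerates an exchange of the fluoro-bearing aryl group for a methyl-bearing one, with the substituent also placed differently on the ring, without a step beyond the scatter. No evidence on the reason for this result is available. Still open, as far as these compounds go, is whether an aryl group carrying an amine or a carboxylic acid at this position would give a step beyond the scatter.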